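Swapping the aryl group on the alkene of a chalcone core

The source may report more compounds than this note shows. Statements on the series, on what has been measured and on what is new or still open speak of the compounds shown alone.

Measured compounds:
- Compound 1 `COc1ccc(/C=C(/C(=O)c2cc(OC)c(OC)c(OC)c2)c2ccccc2O)cc1F`: 60000 nM
- Compound 2 `COc1ccc(/C=C(/C(=O)c2cc(OC)c(OC)c(OC)c2)c2ccc(OC)cc2OC)cc1`: 90000 nM
- Compound 3 `COc1ccc(/C=C(/C(=O)c2cc(OC)c(OC)c(OC)c2)c2ccccc2O)cc1O[Si](C)(C)C(C)(C)C`: 380000 nM

All three were tested in a functional assay on K562 cells (Homo sapiens) for antiproliferative activity, read by MTT assay, with a stated time of 5 days; on this read-out lower numbers stand for stronger inhibition and higher numbers for weaker inhibition. Compound 2 stands second highest of the three numbers: its nearest neighbour is compound 1, whose value lies within the scatter of that of compound 2, while compound 3 sits furthest away, beyond the scatter. Within the data shown here, the only one-place step among the measured compounds runs a 6.3-fold higher number from compound 1 to compound 3 (0.80 log units; beyond the scatter); it concerns the other aromatic ring of the shared core and so does not bear directly on the change at hand.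

Compound 4 `COc1ccc(/C=C(/C(=O)c2cc(OC)c(OC)c(OC)c2)c2ccc(N(C)C)cc2)cc1` differs from compound 2 at the double-bonded chain carbon bound to a carbonyl carbon and a double-bonded chain carbon: 4-(dimethylamino)phenyl in place of 2,4-dimethoxyphenyl on a double-bonded chain carbon bound to a carbonyl carbon and a double-bonded chain carbon. Among the measured compounds shown here, no measured pair shows what this exchange does, so the expectation rests on the general picture that the numbers here lie in a broad, weak range and that a single ring swap on the core has so far moved them only modestly. Compound 4 is therefore expected to give 40000 nM, with a plausible range from 6000 nM to 250000 nM, corresponding to an estimated step of a 2.3-fold lower number from compound 2 to compound 4 (0.35 log units; beyond the scatter), which may well fall within the scatter.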

Compound 4, half-maximal inhibitory concentration: 150000 nM
For compound 4 the middle estimate is 3.8-fold (0.57 log units) below the measured one; measured number inside the range.
By their numbers in this assay, from the lowest: compounds 1, 2 and 4 (each within the scatter of the next, the first and the last beyond it); then compound 3.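

In this assay, among these compounds, replacing 2,4-dimethoxyphenyl with 4-(dimethylamino)phenyl on the double-bonded chain carbon bound to a carbonyl carbon and a double-bonded chain carbon gives a 1.7-fold higher number from compound 2 to compound 4 (0.22 log units; within the scatter) and provides the first direct comparison at this position. Although the leaving group has 2 hydrogen-bond acceptors and oxygen atoms, while the entering group has 1 hydrogen-bond acceptor and a nitrogen atom, this pair cannot be separated in the assay, so the exchange shows no real change in antiproliferative activity. No supporting measurement is available to explain this result.

One pair of groups cannot define what this position tolerates, and compound 1 and compound 3 differ from compound 2 and compound 4 in more than one place, so those comparisons cannot be read. As far as these compounds go, it remains open whether a different substituent on this aromatic ring, such as a carboxylic acid, a primary amine or a longer chain, would move the number beyond the scatter in either direction.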